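Working notes: chloro to bromo on the shared core

A few compounds are considered here, and "the series" means these few. Any claim that something is new, unique, unknown or untested is made for them only; others in the source may bear on it.

Measured so far in an in vitro ADME assay on microsomes from liver (Mus musculus) for pharmacokinetics, read by LC-MS; on this read-out higher numbers stand for fast clearance and lower numbers for slow clearance
- compound 1 `Cc1cccc2c1nc(C)n2-c1ccc(C(=O)NC2CC2)s1` gives 66 mL/min/kg
- compound 2 `Cc1nc2c(F)cccc2n1-c1ccc(C(=O)NC2CC2)s1` gives 37 mL/min/kg
- compound 3 `Cc1nc2c(Cl)cccc2n1-c1ccc(C(=O)NC2CC2)s1` gives 19 mL/min/kg

Compound 3 carries the lowest of the three numbers. Two steps reach it, a 3.5-fold lower number from compound 1 to compound 3 (0.54 log units; beyond the scatter) and a 1.9-fold lower number from compound 2 to compound 3 (0.29 log units; within the scatter), so its standing is firm only against the methyl compound.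

The change bromo in place of chloro on an aromatic carbon turns compound 3 into compound 4 `Cc1nc2c(Br)cccc2n1-c1ccc(C(=O)NC2CC2)s1` and puts bromo in place of chloro on an aromatic carbon of a six-membered aromatic ring of carbon only.

Within the data shown here, the closest precedent is the one measured exchange of one halogen for another, a 1.9-fold lower number from compound 2 to compound 3 (0.29 log units; within the scatter) and that step stayed within the scatter. Among the measured compounds shown here, the step of a 1.8-fold lower number from compound 1 to compound 2 (0.25 log units; within the scatter) also stayed within it, while only the step from methyl to chloro went beyond it. For the measured compounds named here, no bromo compound has been measured yet, so this comparison rests on very few data. No step beyond the scatter is therefore expected in this assay for this exchange. The estimated step is a 1.1-fold lower number from compound 3 to compound 4 (0.05 log units; within the scatter) and its direction is only a weak expectation. Compound 4 is estimated at 17 mL/min/kg (expected range 9 mL/min/kg to 32 mL/min/kg).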

Compound 4, clearance: 26 mL/min/kg
Estimate against measurement, compound 4: 1.5-fold (0.18 log units) below, and the stated range covers the measured number.
By their numbers in this assay, from the lowest: compounds 3, 4, 2 and 1 (each within the scatter of the next, the first and the last beyond it).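

In this assay, the heaviest halogen at this position adds no separation among the halogens: a 1.4-fold higher number from compound 3 to compound 4 (0.14 log units; within the scatter), and a 1.4-fold lower number from compound 2 to compound 4 (0.15 log units; within the scatter), so fluoro, chloro and bromo form one group that these data cannot order. Bromo also gives a second exchange away from methyl that passes the scatter, a 2.5-fold lower number from compound 1 to compound 4 (0.40 log units; beyond the scatter), alongside a 3.5-fold lower number from compound 1 to compound 3 (0.54 log units; beyond the scatter); compound 2 is the exception among the halogens, with a 1.8-fold lower number from compound 1 to compound 2 (0.25 log units; within the scatter) staying within the scatter, so the separation from methyl holds for two of the three halogens and not for all of them. Nothing available explains these steps or the exception.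

The compounds shown leave open how a nitrile, a methoxy group or an amine would read at this aromatic carbon, and whether a plain hydrogen there would sit nearer compound 1 or the halogen group. They also leave open whether the same halogen comparison would hold with a longer chain in place of the cyclopropyl group on the amide.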